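A Bromo to Chloro Swap on Compound 2

A few compounds are considered here, and "the series" means these few. Any claim that something is new, unique, unknown or untested is made for them only; others in the source may bear on it.

Three compounds already have numbers in a functional assay on U-373MG ATCC cells (Homo sapiens) for inhibition, read by MTT assay, with a stated time of 72 h; on this read-out higher numbers stand for weaker inhibition and lower numbers for stronger inhibition. Compound 1 `CC1(C)CC(NC(=O)Nc2cccc(Cl)c2)c2cc(Br)ccc2O1` gives 69000 nM, compound 2 `CC1(C)CC(NC(=O)NCc2ccccc2)c2cc(Br)ccc2O1` gives 27000 nM, and compound 3 `CC1(C)CC(NC(=S)Nc2ccc(C#N)cc2)c2cc(Cl)ccc2O1` gives 10000 nM. Compound 2 therefore holds the middle place, with a weaker result than compound 3 and a stronger one than compound 1. For the measured compounds named here, the only measured step between compounds differing in one place is a 2.6-fold lower number from compound 1 to compound 2 (0.41 log units; beyond the scatter). That modest step changes a group on an amide-type nitrogen, not the halogen, so it bears only loosely on what comes next.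

Compound 4 `CC1(C)CC(NC(=O)NCc2ccccc2)c2cc(Cl)ccc2O1` differs from compound 2 by chloro in place of bromo on an aromatic carbon. Going by the values given here, no measured step isolates this swap. Compound 3 also carries chloro, but it differs in other places too, so it settles nothing. No change beyond the scatter is therefore expected, and the estimated step is a 1.1-fold lower number from compound 2 to compound 4 (0.05 log units; within the scatter). Compound 4 is expected to give about 24000 nM, with an estimated range from 10000 nM to 55000 nM.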

Compound 4, half-maximal inhibitory concentration: 66000 nM
Compound 4: the middle estimate sits 2.8-fold (0.44 log units) below what was measured, and the stated range ends below it.
By their numbers in this assay, from the lowest: compound 3; then compound 2; then compounds 4 and 1 (each within the scatter of the next).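

In this assay the swap of chloro in place of bromo on this aromatic carbon gives a 2.4-fold higher number from compound 2 to compound 4 (0.39 log units; beyond the scatter) and so counts as a modest loss of inhibition. For the compounds shown here, this is the first sign that the halogen at this position matters, as the only earlier step concerned the group on an amide-type nitrogen. Nothing measured here explains why the chloro compound is weaker.

Going by these compounds, compounds 2 and 4 form a single pair, so it remains open whether the same swap would have a similar effect with the nitrogen substituents of compound 1 or compound 3. The compounds shown also leave open how a fluoro, methyl or methoxy group on this aromatic carbon would compare with bromo and chloro.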